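This account rests on a few compounds, and the source may have more. Where it says the series, first, only, none or still open, it means among the compounds named here.

Measured so far in an ADME assay on Huh-7 cells (Homo sapiens) for cytotoxicity, read by a luciferase reporter and WST assay, with a stated time of 3 days; a lower number here means that less compound is tolerated, a higher number that more compound is tolerated:

- compound 1 `Cc1ccc(NC(=O)c2c(NO)cc(-c3ccc(Cl)cc3)oc2=O)cc1`: compound 1 gives > 20000 nM, a limit of the assay and not a number.
- compound 2 `O=C(NCCO)c1c(NO)cc(-c2ccc(F)cc2)oc1=O`: compound 2 gives > 20000 nM, again a limit.
- compound 3 `O=C(NCCO)c1c(NO)cc(-c2ccc(Cl)cc2)oc1=O`: compound 3 gives > 20000 nM, also a limit.

Compound 3 therefore stands at the ceiling of what was tested, and so do the two compounds around it; see (the limit of > 20000 nM in this assay, at which 3 of the 3 values shown sit). Two measured steps lead to compound 3. The step that the two limits leave unreadable from compound 1 to compound 3 and the step that the two limits leave unreadable from compound 2 to compound 3 both end at limits on either side, so neither can be read as a size or a direction because of the limit of > 20000 nM in this assay, at which 3 of the 3 values shown sit.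

The next compound is compound 4 `COC(=O)CNC(=O)c1c(NO)cc(-c2ccc(Cl)cc2)oc1=O`. It differs from compound 3 by methoxycarbonyl in place of hydroxymethyl on a saturated chain carbon bound to an amide-type nitrogen. Within the data shown here, the step is in the same part of the molecule as the one from compound 1 to compound 3, which gave no readable change, and the rest of the structure is untouched.

On this basis compound 4 is expected to sit where compound 3 sits, with a step that the limit leaves unreadable from compound 3 to compound 4 that the assay is unlikely to resolve. The estimate for compound 4 in this assay is 30000 nM, within 10000 nM to 100000 nM, most probably reported again as a limit rather than a number.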

Compound 4, half-maximal cytotoxic concentration: > 20000 nM
Compound 4: only a limit was reported; the forecaster's own chance of this, stated with the estimate: 85%; the middle value does not contradict the limit.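

In this assay compound 4 gives > 20000 nM, a limit and not a number. The steps to compound 4 from compound 3 and from compound 1 therefore cannot be read: the limit of > 20000 nM in this assay, at which 4 of the 4 values shown sit.

The compounds shown leave open where the half-maximal cytotoxic concentration of compound 1, compound 2, compound 3 and compound 4 actually lies, and whether any change among them shifts it.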